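Swapping Bromine for Chlorine on a Thioxothiazolidinone Benzylidene

This account rests on a few compounds, and the source may have more. Where it says the series, first, only, none or still open, it means among the compounds named here.

Measured so far:
compound 1, `O=C1NC(=S)/C(=C/c2cc(Cl)cc(Cl)c2Cl)S1`, gives 12.6%
compound 2, `O=C1NC(=S)/C(=C/c2ccccc2Br)S1`, gives 3.14%

Both were tested in a functional assay on HEp-2 cells (Homo sapiens) for cytotoxicity, read by MTT assay, with a stated time of 72 h, tested at 1.25 ug/mL; on this read-out higher numbers stand for more inhibition of growth at the one concentration tested and lower numbers for less inhibition of growth. The gap between compound 2 and compound 1 lies within the usual scatter, so the two cannot be told apart on these numbers. Compound 3, `O=C1NC(=S)/C(=C/c2ccccc2Cl)S1`, is not yet measured. It differs from compound 2 by chloro in place of bromo on an aromatic carbon. Going by the values given here, with no measured pair showing the effect of such a swap, no step beyond the scatter is expected from compound 2 to compound 3, in either direction, so the estimated step is a number 1.9 percentage points higher from compound 2 to compound 3 (within the scatter). For compound 3 the expected result is 5%, likely between -5% and 15%.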

Compound 3, percent growth inhibition at one concentration: -11.3%
Estimate against measurement, compound 3: 16.3 percentage points above; measured number outside the range, below it.
By their numbers in this assay, from the lowest: compound 3; then compounds 2 and 1 (each within the scatter of the next).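

In this assay chloro in place of bromo, on an aromatic carbon ortho to a group of 8 heavy atoms, gives a number 14.4 percentage points lower from compound 2 to compound 3 (beyond the scatter) and so shows a real change. A swap of one halogen for another at this position can therefore move the read-out, although the step is modest and rests on a single pair. No measurement at hand gives a reason for this step. As far as these compounds go, how an amine or a carboxylic acid at this position would compare remains open. So does whether the same swap on another aromatic carbon would move the number in the same direction.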